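A few compounds are considered here, and "the series" means these few. Any claim that something is new, unique, unknown or untested is made for them only; others in the source may bear on it.

Measured compounds in a functional assay on A549 cells (Homo sapiens) for antiproliferative activity, read by MTT assay, with a stated time of 72 h; on this read-out higher numbers stand for weaker inhibition and lower numbers for stronger inhibition:
compound 1 `O=C(Nc1ccccc1)C(Cl)Cl` — 130000 nM
compound 2 `Cc1ccccc1NC(=O)C(Cl)Cl` — "not determined" (no result reported)
compound 3 `O=C(Nc1ccccc1Br)C(Cl)Cl` — 37000 nM

Compound 3 gives the lowest of the two numbers in this assay; its nearest neighbour is compound 1, separated by the step of a 3.5-fold lower number from compound 1 to compound 3 (0.55 log units; beyond the scatter), which goes beyond the scatter. Compound 2 contributes no number.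

Compound 4 `O=C(Nc1ccccc1[N+](=O)[O-])C(Cl)Cl` differs from compound 3 as follows: nitro in place of bromo on an aromatic carbon. For the measured compounds named here, no measured step swaps one such substituent for another; the only step in hand, a 3.5-fold lower number from compound 1 to compound 3 (0.55 log units; beyond the scatter), concerns the entry of the bromo group against hydrogen and therefore bears on this change only loosely. For nitro against bromo at the same place, a step within the scatter, or at most a small one in either direction, is expected: a 1.2-fold lower number from compound 3 to compound 4 (0.09 log units; within the scatter). Compound 4 is estimated at 30000 nM, with a range from 8000 nM to 110000 nM.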

Compound 4, half-maximal inhibitory concentration: 198000 nM
For compound 4 the middle estimate is 6.6-fold (0.82 log units) below the measured one; the whole stated range lies below it.
By their numbers in this assay, from the lowest: compound 3; then compounds 1 and 4 (each within the scatter of the next).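

Bromo and nitro are not interchangeable on this aromatic carbon: the swap gives a clear step (a 5.4-fold higher number from compound 3 to compound 4 (0.73 log units; beyond the scatter)), so the stronger inhibition of compound 3 does not extend to nitro. Against the unsubstituted core, nitro brings no difference that can be told from scatter (a 1.5-fold higher number from compound 1 to compound 4 (0.18 log units; within the scatter)), so among these compounds only bromo separates from hydrogen. No measurement on hand accounts for the difference between the two groups.

Open, from the compounds shown here alone, is how chloro, an amine or a methoxy group would read at this place. Also open, going by these compounds, is how bromo or nitro would read on the other ring carbons.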